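Methyl in place of methoxy: an expectation for compound 4

A few compounds are considered here, and "the series" means these few. Any claim that something is new, unique, unknown or untested is made for them only; others in the source may bear on it.

Compound 1 `C=C1C[C@]23C[C@@]1(O)CC[C@H]2c1ccc(O)c(C)c1[C@@H]3Cn1cc(-c2ccc(C(F)(F)F)cc2)nn1`: in a functional assay on A549 cells (Homo sapiens) for cytotoxicity, read by MTT assay, with a stated time of 4 days (a higher number here means a weaker inhibitor, a lower number a stronger inhibitor), compound 1 gives 10400 nM.
Compound 2 `C=C1C[C@]23C[C@@]1(O)CC[C@H]2c1cc(Br)c(O)c(C)c1[C@@H]3Cn1cc(-c2ccc(OC)cc2)nn1`: in this assay compound 2 gives > 20000 nM, which is a limit of the assay and not a number.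
Compound 3 `C=C1C[C@]23C[C@@]1(O)CC[C@H]2c1ccc(O)c(C)c1[C@@H]3Cn1cc(-c2ccc(OC)cc2)nn1`: in this assay compound 3 gives > 20000 nM, again a limit and not a number.

Compound 2 thus stands at the limit of > 20000 nM in this assay, at which 2 of the 3 values shown sit, and only compound 1 has a readable number. Compound 4 `C=C1C[C@]23C[C@@]1(O)CC[C@H]2c1cc(Br)c(O)c(C)c1[C@@H]3Cn1cc(-c2ccc(C)cc2)nn1` differs from compound 2 by methyl in place of methoxy on an aromatic carbon. Within the data shown here, no measured step exchanges methoxy for methyl, so the nearest evidence is indirect. The step of an at least 1.9-fold higher number from compound 1 to compound 3 (0.28 log units; that floor lies within the scatter) exchanges one para group on the same phenyl for methoxy and reaches only the floor within the scatter. The step that the two limits leave unreadable from compound 2 to compound 3, the bromo-to-hydrogen change on the core, cannot be read because both ends are limits. With compound 2 itself at the limit, a methyl in place of methoxy is expected to shift the number little. Compound 4 is therefore expected at 18000 nM, in the range 7000 nM to 45000 nM. The step from compound 2 to compound 4 is expected to be an at least 1.1-fold lower number from compound 2 to compound 4 (0.04 log units; that floor lies within the scatter), with a fair chance that only a limit is reported.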

Compound 4, half-maximal inhibitory concentration: > 20000 nM
Compound 4 ended at the assay's limit; the forecaster's own chance of this, stated with the estimate: 55%; middle value at least 1.1-fold (0.04 log units) from the limit.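

Compound 2 and compound 4 both end at a limit of the assay and not at a number, so no step between them can be read: the limit of > 20000 nM in this assay, at which 3 of the 4 values shown sit.

The compounds shown leave open what methyl in place of methoxy does to the number at all.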